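The source may hold more compounds than are shown below. What is called first, only, known or untested is meant among the compounds shown, and "the series" means these compounds.

Measured so far in a functional assay on A549 cells (Homo sapiens) for antiproliferative activity, read by MTT assay, with a stated time of 48 h; on this read-out lower numbers stand for stronger inhibition and higher numbers for weaker inhibition:

compound 1, `CN1C(=O)C2(C(C#N)=C(N)Oc3cc4oc(-c5ccccc5)cc(=O)c4c(O)c32)c2cc(Cl)ccc21`, gives 4720 nM
compound 2, `CN1C(=O)C2(C(C#N)=C(N)Oc3cc4oc(-c5ccccc5)cc(=O)c4c(O)c32)c2cc(Br)ccc21`, gives 3150 nM
compound 3, `N#CC1=C(N)Oc2cc3oc(-c4ccccc4)cc(=O)c3c(O)c2C12C(=O)Nc1cc(Cl)ccc12`, gives 8470 nM

Compound 1 and compound 2 share one core and differ in a single place: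

bromo in place of chloro on an aromatic carbon

That change made a 1.5-fold lower number from compound 1 to compound 2 (0.18 log units; within the scatter), a step too small to count as a real difference in this assay.

Compound 3 is built on a different core, and how its core differs from that of compound 1 is not broken down here. In this assay compound 3 gives a number that lies within the scatter of that of compound 1, while against compound 2 the gap is beyond the scatter, so compound 3 sits above compound 2.

Compound 4, `N#CC1=C(N)Oc2cc3oc(-c4ccccc4)cc(=O)c3c(O)c2C12C(=O)Nc1cc(Br)ccc12`, has not been measured. It stands to compound 3 exactly as compound 2 stands to compound 1, since the change is the same change at the same place:

bromo in place of chloro on an aromatic carbon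

Because the same change earlier gave a 1.5-fold lower number from compound 1 to compound 2 (0.18 log units; within the scatter), a step of similar size is expected, a 1.5-fold lower number from compound 3 to compound 4 (0.18 log units; within the scatter). Compound 4 is therefore estimated at 5600 nM, most likely between 2800 nM and 11500 nM.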

Compound 4, half-maximal inhibitory concentration: 9340 nM
Estimate against measurement, compound 4: 1.7-fold (0.22 log units) below; the range from low to high includes it.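

In this assay the bromo-for-chloro exchange on the second core gives a 1.1-fold higher number from compound 3 to compound 4 (0.04 log units; within the scatter), a step too small to count as a real difference. Set beside the earlier step on the core of compound 1, the two results do not differ: the same change on two cores in this assay, a 1.5-fold lower number (0.18 log units; within the scatter) from compound 1 to compound 2 and a 1.1-fold higher number (0.04 log units; within the scatter) from compound 3 to compound 4, 1.7-fold (0.22 log units) apart, within the scatter of two such steps. So on these two cores the exchange behaves alike, leaving the number essentially unchanged, but two small steps show neither that bromo and chloro would match on any other core nor that this position is unimportant in general.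

The compounds shown carry only chloro or bromo on this aromatic carbon, so it remains open what a fluoro, a methoxy or an amine would do there, where a larger step might appear. Also open, as far as these compounds go, is whether a longer chain, such as propyl, in place of the methyl on the amide nitrogen of compound 1 would move the number.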